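Swapping methoxy for isopropyl on the shared core

A few compounds are considered here, and "the series" means these few. Any claim that something is new, unique, unknown or untested is made for them only; others in the source may bear on it.

Of the compounds shown here, three built on a shared core have been tested in a toxicity assay on MDCK cells (Canis lupus familiaris) for cytotoxicity, read by crystal violet staining, with a stated time of 48 h; on this read-out higher numbers stand for lower toxicity in this test and lower numbers for higher toxicity in this test. Compound 1 `CC(C)c1ccc2[nH]c(=O)c(CN(Cc3ccc(F)cc3)Cc3ccc(C(C)(C)C)cc3)cc2c1` gives 7900 nM. Compound 2 `CC(C)c1ccc2[nH]c(=O)c(CN(Cc3ccc(C(C)(C)C)cc3)C(C)c3ccc(F)cc3)cc2c1` gives 13100 nM; the change of methyl in place of hydrogen on a saturated chain carbon bound to an amine nitrogen and an aromatic carbon brings a 1.7-fold higher number from compound 1 to compound 2 (0.22 log units; within the scatter). Compound 3 `COc1ccc([C@H](C)N(Cc2ccc(C(C)(C)C)cc2)Cc2cc3cc(OC)ccc3[nH]c2=O)cc1` gives 4100 nM, the lowest of the three numbers; its gap to compound 1 lies within the scatter, while its gap to compound 2 lies beyond it.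

Compound 4 `COc1ccc([C@H](C)N(Cc2ccc(C(C)(C)C)cc2)Cc2cc3cc(C(C)C)ccc3[nH]c2=O)cc1` has not yet been measured in this assay. It differs from compound 3 by isopropyl in place of methoxy on an aromatic carbon. Within the data shown here, no measured pair isolates this change: the one measured step, a 1.7-fold higher number from compound 1 to compound 2 (0.22 log units; within the scatter), concerns the chain carbon, not the core. Compounds 1 and 2 carry the isopropyl that enters in compound 4, but they also differ from compound 3 elsewhere, so their numbers only hint at a range. Compound 4 is therefore expected to show a small step, a 1.7-fold higher number from compound 3 to compound 4 (0.23 log units; within the scatter), within the scatter. The estimate for compound 4 is 7000 nM, between 3000 nM and 16000 nM.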

Compound 4, half-maximal cytotoxic concentration: > 10000 nM
Compound 4 ended at the assay's limit; the forecaster's own chance of this, stated with the estimate: 5%; at least 1.4-fold (0.15 log units) between middle value and limit.
By their numbers in this assay, from the lowest: compounds 3, 1 and 2 (each within the scatter of the next, the first and the last beyond it).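

In this assay compound 4 stands at a limit of the assay and not at a number, as set by this line: the limit of > 10000 nM in this assay, at which 1 of the 4 values shown sits.

Among these compounds, for isopropyl in place of methoxy on this aromatic carbon of the shared core, the earlier compounds offered no pair, and this one gives an at least 2.4-fold higher number from compound 3 to compound 4 (0.38 log units; beyond the scatter), so this single change moves the number beyond the scatter, towards lower toxicity in this test, and its full size stays unknown. The comparison on the amine nitrogen, 1-(4-methoxyphenyl)ethyl in place of 4-fluorobenzyl, gives only an at least 1.2-fold higher number from compound 1 to compound 4 (0.10 log units; that floor lies within the scatter), so it shows no change that can be told from the scatter, and the step from compound 2 cannot be read.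

The compounds shown leave open what number lies behind the limit of compound 4, and whether the same swap on the core gives a similar step when 1-(4-fluorophenyl)ethyl sits on the amine nitrogen. They also leave open how a hydroxyl, an ethyl or a chlorine on this aromatic carbon would compare with methoxy and isopropyl.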